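Cyano in place of hydrogen on compound 1

This account rests on a few compounds, and the source may have more. Where it says the series, first, only, none or still open, it means among the compounds named here.

In a physicochemical assay for acid dissociation, compound 1 `C[C@@]1(c2cc(NC(=O)c3ccc(C#N)cn3)ccc2F)Cn2ccnc2C(N)=N1` gives 8.2. Compound 2 `C[C@@]1(c2cccc(NC(=O)c3ccc(C#N)cn3)c2)Cn2nccc2C(N)=N1` gives 8.5, so the two values lie within the scatter of each other. Among the compounds with values here, no measured pair differs in one place only, which leaves the series without a measured step to serve as a guide. Compound 3 `C[C@@]1(c2cc(NC(=O)c3ccc(C#N)cn3)ccc2F)Cn2c(C#N)cnc2C(N)=N1` keeps the core of compound 1 and has cyano in place of hydrogen on an aromatic carbon. That carbon belongs to a five-membered aromatic ring with 2 nitrogen, part of a fused system of two rings. In this assay, a downward step well beyond the scatter is expected. The estimated change is a number 2.30 log units lower from compound 1 to compound 3 (beyond the scatter), and it rests on the structural change alone, so the range is kept wide. Compound 3 is expected at 5.9, within an estimated range of 5 to 6.8.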

Compound 3, acid dissociation constant: 7.2
Beside the measured number, compound 3's estimate is 1.30 log units below it; the whole stated range lies below it.
By their numbers in this assay, from the lowest: compound 3; then compounds 1 and 2 (each within the scatter of the next).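

In this assay, within the data shown here, replacing hydrogen with cyano on an aromatic carbon of the five-membered ring gives the first measured single-place step: a number 1.00 log units lower from compound 1 to compound 3 (beyond the scatter). Among these compounds, the earlier pair differed in more than one place, so only this step shows that the number responds to a change at this carbon, next to the ring nitrogen, with the rest of compound 1 held constant. The step is beyond the scatter, yet it is a single observation for one group at one position. No supporting measurement is available to explain its size.

Still open, as far as these compounds go, is whether a methyl group, a chlorine atom or an amine on the same carbon would shift the number in the same direction. Also open, from the compounds shown here alone, is whether cyano would produce a similar step on a different core.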